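The source may hold more compounds than are shown below. What is called first, only, known or untested is meant among the compounds shown, and "the series" means these compounds.

In a functional assay on L02 cells (Homo sapiens) for inhibition (on this read-out lower numbers stand for stronger inhibition and higher numbers for weaker inhibition), compound 1 (`CN(C(=O)CC(CC(=O)NCCN1CCCC1)c1ccccc1)C1Cc2ccccc2C1`) is reported only as a limit of the assay, > 100000 nM. Compound 2 (`CN(C(=O)CC(CC(=O)NCCN1CCCC1)c1ccc(Cl)cc1)C1Cc2ccccc2C1`) gives a number, 81500 nM. Compound 3 (`CCN(CC)CCNC(=O)CC(CC(=O)N(C)C1Cc2ccccc2C1)c1ccccc1`) is also reported only as a limit, > 100000 nM. It therefore stands at the limit of > 100000 nM in this assay, at which 2 of the 3 values shown sit, and its true position is not known.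

Compound 4 (`CCN(CC)CCNC(=O)CC(CC(=O)N(C)C1Cc2ccccc2C1)c1ccc(Cl)cc1`) differs from compound 3 by one change, chloro in place of hydrogen on an aromatic carbon, so that phenyl becomes 4-chlorophenyl. The same exchange has been measured once, as an at least 1.2-fold lower number from compound 1 to compound 2 (0.08 log units; that floor lies within the scatter). The other measured step, a step that the two limits leave unreadable from compound 1 to compound 3, gives no size to work from. On the evidence of the first step alone, a small move towards stronger inhibition in this assay is expected, and it may not exceed the scatter. The estimated step is an at least 1.3-fold lower number from compound 3 to compound 4 (0.12 log units; that floor lies within the scatter). Compound 4 is expected at about 75000 nM. The estimated range for compound 4 runs from 40000 nM to 100000 nM.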

Compound 4, half-maximal inhibitory concentration: 56500 nM
For compound 4 the middle estimate is 1.3-fold (0.12 log units) above the measured one; low and high end bracket the measured number.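

In this assay, the exchange of phenyl for 4-chlorophenyl now also yields a measured number on a second core, as an at least 1.7-fold lower number from compound 3 to compound 4 (0.24 log units; that floor lies within the scatter). The same change can therefore be set side by side on two cores, though not sized exactly: the same change on two cores in this assay, an at least 1.2-fold lower number (0.08 log units; that floor lies within the scatter) from compound 1 to compound 2 and an at least 1.7-fold lower number (0.24 log units; that floor lies within the scatter) from compound 3 to compound 4; the limit leaves it open whether they differ The exchange of pyrrolidin-1-yl for diethylamino, unreadable on the phenyl pair, can now be read on the 4-chlorophenyl pair, as a 1.4-fold lower number from compound 2 to compound 4 (0.16 log units; within the scatter), so with chloro in place the two amines are not told apart.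

From the compounds shown here alone, the true size of the chloro step stays open on both cores, since each starts from a compound reported only as a limit: the limit of > 100000 nM in this assay, at which 2 of the 4 values shown sit. Also open is whether fluoro or methoxy in place of chloro, or piperidin-1-yl or a longer chain at the amine end, would shift the number beyond the scatter.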